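The source may report more compounds than this note shows. Statements on the series, on what has been measured and on what is new or still open speak of the compounds shown alone.

Of the compounds shown here, two have so far been measured in an assay on HT-29 cells with Methylated-DNA--protein-cysteine methyltransferase (Homo sapiens) as the target, with a stated time of 4 h; on this read-out lower numbers stand for an effect already at smaller amounts and higher numbers for an effect only at larger amounts of compound. Compound 1 `Nc1nc(OCc2ccccc2)c2[nH]c(N)nc2n1` gives 2 uM in this assay. Compound 2 `Nc1nc(N)c(N)c(OCc2ccccc2)n1` gives 0.3 uM in this assay. Compound 2 therefore stands at the lower of the two numbers, and compound 1 sits at a number higher by a margin that lies beyond the usual scatter of this kind of measurement. Going by the values given here, no pair of measured compounds differs in only one place, so no measured single change is available to guide the next one.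

Compound 3 `Nc1nc(N)c(Br)c(OCc2ccccc2)n1` has not yet been measured. It differs from compound 2 in one place: bromo in place of amino on an aromatic carbon. Among the compounds with values here, with only two measured compounds and no single-point step behind it, the direction of this change cannot be read from the numbers. The replacement is expected to shift the number only modestly, and in this assay the expected step is a 1.7-fold higher number from compound 2 to compound 3 (0.22 log units; within the scatter), a movement that would remain within the usual scatter. Compound 3 is accordingly expected to come in at 0.5 uM, within a range from 0.1 uM to 2.5 uM.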

Compound 3, concentration for half-maximal effect: 0.8 uM
Beside the measured number, compound 3's estimate is 1.6-fold (0.20 log units) below it, and the stated range covers the measured number.
By their numbers in this assay, from the lowest: compound 2; then compound 3; then compound 1.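

In this assay, going by these compounds alone, this is the first change that can be read at a single place: on an aromatic carbon ortho to a group of 8 heavy atoms and two atoms from the ring nitrogen, bromo in place of amino gives a 2.7-fold higher number from compound 2 to compound 3 (0.43 log units; beyond the scatter). The amino group counts one hydrogen-bond donor and one hydrogen-bond acceptor and bromo counts neither, so this position accepts that exchange at the cost of only a modest step, not a loss of the read-out. Nothing measured here accounts for the size or direction of this step.

The compounds shown leave open how a chloro group, a nitro group or a plain hydrogen on this aromatic carbon would compare with amino and bromo, and so whether the step follows from the amino group leaving or from the bromo group entering. They also leave open whether the same exchange would give a step of similar size on the core of compound 1, or with another group in place of the group of 8 heavy atoms.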